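Amide variation: from compound 2 to compound 4

The compounds below may be only part of what the source reports. "The series", "measured", "known", "first", "only" and "open" are said of these compounds alone.

compound 1 `Nc1sc(-c2ccc(Cl)cc2)c(-c2ccc(Cl)cc2)c1C(=O)N1CCCCC1` gives 14300 nM
compound 2 `CCCCNC(=O)c1c(N)sc(-c2ccc(Cl)cc2)c1-c1ccc(Cl)cc1` gives 17800 nM
compound 3 `CCN(CC)CCNC(=O)Nc1sc(-c2ccc(Cl)cc2)c(-c2ccc(Cl)cc2)c1C(=O)NC1CC1` is recorded as "not determined" (no result reported)

Going by the values given here, in a functional assay on PC-3 cells (Homo sapiens) for inhibition, read by sulforhodamine B assay, with a stated time of 72 h (a lower number here means a stronger inhibitor, a higher number a weaker inhibitor), compound 2 (17800 nM) lies within the scatter of compound 1 (14300 nM), and these are the only two numbers available. Among the compounds with values here, compound 3 therefore contributes no step.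

The next compound is compound 4 `Nc1sc(-c2ccc(Cl)cc2)c(-c2ccc(Cl)cc2)c1C(=O)NCc1ccccc1`, which keeps the shared core and changes only the amide substituent of compound 2. The difference is phenyl in place of propyl on a saturated chain carbon bound to an amide-type nitrogen (phenyl in place of propyl on a saturated chain carbon bound to an amide-type nitrogen, which also reads as butyl to benzyl).

Within the data shown here, one measured step bears on this change: a 1.2-fold higher number from compound 1 to compound 2 (0.10 log units; within the scatter) (butylamino in place of piperidin-1-yl on a carbonyl carbon). That exchange at the same amide stayed within the scatter. Among the measured compounds shown here, it is only a weak guide, since no measured compound carries an aromatic ring on the amide chain, and two numbers define no trend.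

The expected step is a 1.2-fold lower number from compound 2 to compound 4 (0.07 log units; within the scatter) and no shift beyond the scatter is expected in this assay in either direction. The estimate for compound 4 is 15000 nM (expected range 7000 nM to 32000 nM).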

Compound 4, half-maximal inhibitory concentration: 31800 nM
Compound 4: middle estimate off by 2.1-fold (0.33 log units), on the low side, and the stated range covers the measured number.
By their numbers in this assay, from the lowest: compounds 1, 2 and 4 (each within the scatter of the next, the first and the last beyond it).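

In this assay, going by these compounds alone, the exchange of butyl for benzyl on the amide nitrogen gives a 1.8-fold higher number from compound 2 to compound 4 (0.25 log units; within the scatter) and so stays inside the scatter, which shows that an aromatic ring on the amide chain, absent from the earlier compounds, still gives a readable number of the same order as the butyl amide. Set against the piperidin-1-yl amide, the same benzylamino group gives a 2.2-fold higher number from compound 1 to compound 4 (0.35 log units; beyond the scatter) in this assay, the first step in this set to pass beyond the scatter, and it is modest in size; because compound 2 lies within the scatter of both compound 1 and compound 4, the three amides form a narrow band rather than clearly separated levels. No measured data on these compounds offer an explanation for this step.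

Still open, going by these compounds, is whether any amide group at this position moves the number by more than a modest step, for example a longer chain such as octyl, a phenethyl group, or a chain ending in an amine or a carboxylic acid. Also open, on these data alone, is whether a substituent on the benzyl ring, such as chloro or methoxy, changes the reading relative to the unsubstituted benzyl of compound 4.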